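A few compounds are considered here, and "the series" means these few. Any claim that something is new, unique, unknown or untested is made for them only; others in the source may bear on it.

Compound 1 `Clc1ccc(Nc2nc(-c3ccccn3)cs2)nc1`: < 10000 nM
Compound 2 `COc1cccc(-c2csc(Nc3ccc(Cl)cn3)n2)n1`: < 10000 nM
Compound 3 `FC(F)(F)c1ccc(-c2csc(Nc3ccc(Cl)cn3)n2)nc1`: < 10000 nM

In a physicochemical assay for solubility, in phosphate buffer, with a stated time of 2 h, at pH 7.4 (on this read-out lower numbers stand for lower solubility and higher numbers for higher solubility), compound 1 gives < 10000 nM, which is a limit of the assay and not a number. It has company, as the series shows (the limit of < 10000 nM in this assay, at which 3 of the 3 values shown sit). Compound 4 `Clc1ccc(Nc2nc(-n3cccn3)cs2)nc1` differs from compound 1 in one place, with 1H-pyrazol-1-yl in place of pyridin-2-yl on an aromatic carbon. The measured steps that bear on this are a step that the two limits leave unreadable from compound 1 to compound 2 and a step that the two limits leave unreadable from compound 1 to compound 3. Neither gives a size or a direction, so no step beyond the usual scatter is expected, and the expected step is a step that the limit leaves unreadable from compound 1 to compound 4. Compound 4 is estimated at 5000 nM, with an expected range from 1000 nM to 12000 nM.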

Compound 4, solubility: < 10000 nM
Compound 4: only a limit was reported; the forecaster's own chance of this, stated with the estimate: 75%; the middle value lies beyond the limit too.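

For the compounds shown here, compound 1 and compound 4 each give only a limit of the assay, not a number, so no step between them can be read. Whether any of these group changes alters solubility stays open, as every value shown is that same limit: the limit of < 10000 nM in this assay, at which 4 of the 4 values shown sit.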